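The source may hold more compounds than are shown below. What is called first, only, known or untested is meant among the compounds shown, and "the series" means these compounds.

Measured so far:
- Compound 1 `O=C1/C(=C/c2cccnc2)CN(S(=O)(=O)c2ccc([N+](=O)[O-])cc2)C/C1=C\c1ccccc1F`: > 20000 nM, a limit of the assay and not a number
- Compound 2 `O=C1/C(=C/c2ccncc2)CN(S(=O)(=O)c2ccccc2)C/C1=C\c1ccccc1F`: 17500 nM
- Compound 3 `Cc1ccc(S(=O)(=O)N2C/C(=C\c3ccncc3)C(=O)/C(=C/c3ccccc3F)C2)cc1`: 13200 nM

In a functional assay on SMMC-7721 cells (Homo sapiens) for cytotoxicity, read by MTT assay, with a stated time of 24 h (a higher number here means a weaker inhibitor, a lower number a stronger inhibitor), compound 3 gives 13200 nM, level with compound 2 within the scatter. Compound 4 `O=C1/C(=C/c2ccncc2)CN(S(=O)(=O)c2ccc([N+](=O)[O-])cc2)C/C1=C\c1ccccc1F` has nitro in place of methyl on an aromatic carbon. Among the measured compounds shown here, the one measured step, methyl in place of hydrogen on an aromatic carbon, is small: a 1.3-fold lower number from compound 2 to compound 3 (0.12 log units; within the scatter). Compound 1, which also carries 4-nitrophenyl, offers only a limit, > 20000 nM. Neither fixes a size or direction, so no change beyond the scatter is expected. The estimated step is a 1.1-fold higher number from compound 3 to compound 4 (0.06 log units; within the scatter). For compound 4 the expected value is 15000 nM, with an estimated range of 7000 nM to 30000 nM.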

Compound 4, half-maximal inhibitory concentration: 15800 nM
Compound 4: the middle estimate sits 1.1-fold (0.02 log units) below what was measured; measured number inside the range.
By their numbers in this assay, from the lowest: compounds 3, 4 and 2 (each within the scatter of the next). At a limit, above all of these: compound 1.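

On this aromatic ring, hydrogen, methyl and nitro now read as level in this assay: a 1.2-fold higher number from compound 3 to compound 4 (0.08 log units; within the scatter), and a 1.1-fold lower number from compound 2 to compound 4 (0.04 log units; within the scatter). Among the compounds shown here, compound 1, the only earlier compound with 4-nitrophenyl, gave just a limit of the assay, > 20000 nM. Pyridin-4-yl in place of pyridin-3-yl therefore reads only as a floor, which does not show a real change: an at least 1.2-fold lower number from compound 1 to compound 4 (0.10 log units; that floor lies within the scatter).

As far as these compounds go, whether an amine or a carboxylic acid at this place on the ring would move the number beyond the scatter stays open. So does the true size of the pyridin-3-yl to pyridin-4-yl step.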